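Removing the benzylsulfanyl arm from compound 1

The source may hold more compounds than are shown below. What is called first, only, known or untested is meant among the compounds shown, and "the series" means these compounds.

The study examines a small set of fused bicyclic compounds carrying an anilino-type pyrazole and a thioether substituent. Compound 1 `Cc1cc(Nc2cc(-c3ccccc3)[nH]n2)n2nc(SCc3c(Cl)cccc3Cl)nc2n1` gives 5180 nM in a functional assay on PC-9 cells (Homo sapiens) for inhibition, read by MTT assay, with a stated time of 72 h; a higher number here means a weaker inhibitor, a lower number a stronger inhibitor. Compound 2 `Cc1cc(Nc2ccn(Cc3nc(C)c4ccccc4n3)n2)n2nc(SCc3ccc(Br)cc3)nc2n1` gives 5450 nM in this assay, a number that sits within the scatter of the value of compound 1, so no order between the two can be stated. Compound 3 `Cc1nc2nc(SCc3ccc(Cl)cc3)nn2c(Nc2cc(-c3ccccc3)[nH]n2)c1C` reaches only the limit of > 50000 nM in this assay, which is a limit rather than a number; this is the situation described by the limit of > 50000 nM in this assay, at which 1 of the 3 values shown sits.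

Compound 4 `Cc1cc(Nc2cc(-c3ccccc3)[nH]n2)n2ncnc2n1` has not yet been measured. It differs from compound 1 by hydrogen in place of (2,6-dichlorobenzyl)sulfanyl on an aromatic carbon. Going by the values given here, no measured pair in the set shows what this kind of change does, so the expectation rests only on the magnitude of what is removed. The account expects the step from compound 1 to compound 4 in this assay to go toward a weaker inhibitor, a 3.9-fold higher number from compound 1 to compound 4 (0.59 log units; beyond the scatter), and well beyond the scatter. For compound 4 the estimated value in this assay is 20000 nM, within a range from 4000 nM to 100000 nM.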

Compound 4, half-maximal inhibitory concentration: > 50000 nM
Compound 4 gave a limit, no number; the forecaster's own chance of this, stated with the estimate: 35%; at least 2.5-fold (0.39 log units) between middle value and limit.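

Going by these compounds alone, the earlier compounds offered no pair differing in one place, so this is the first direct reading for this position on an aromatic carbon between two ring nitrogen atoms. In this assay, hydrogen in place of (2,6-dichlorobenzyl)sulfanyl gives an at least 9.6-fold higher number from compound 1 to compound 4 (0.98 log units; beyond the scatter), so the core of compound 1 does not keep its measured activity once this arm is gone. For compound 4 the reading is a limit and not a number: the limit of > 50000 nM in this assay, at which 2 of the 4 values shown sit.

The compounds shown leave open whether the step follows the sulfur link or the dichlorobenzyl ring, which a small group such as an amine or methylsulfanyl at the same carbon would help to separate. No pair shown changes the chlorine atoms alone either.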